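The source may report more compounds than this note shows. Statements on the series, on what has been measured and on what is new or still open speak of the compounds shown alone.

Working notes on the series. Compound 1 `CCCCc1ccc(CNC(C)=O)c(=O)n1Cc1ccc(-c2ccccc2-c2nn[nH]n2)cc1` carries acetamido on a saturated chain carbon bound to an aromatic carbon; in a functional assay (aorta) for antagonist activity, with Oryctolagus cuniculus as the target (a higher number here means a weaker inhibitor, a lower number a stronger inhibitor), compound 1 gives 3 nM. Compound 2 `CCCCc1ccc(CN(Cc2ccccc2)S(C)(=O)=O)c(=O)n1Cc1ccc(-c2ccccc2-c2nn[nH]n2)cc1` carries benzyl(methylsulfonyl)amino at that place, and in this assay compound 2 gives 2 nM. Compound 3 `CCCCc1ccc(C)c(=O)n1Cc1ccc(-c2ccccc2-c2nn[nH]n2)cc1` carries hydrogen there, and in this assay compound 3 gives 7 nM. Compound 2 shows the lowest of the three numbers, though the gap a 1.5-fold lower number from compound 1 to compound 2 (0.18 log units; within the scatter) is within the scatter, while a 3.5-fold higher number from compound 2 to compound 3 (0.54 log units; beyond the scatter) is beyond it; the third step is a 2.3-fold higher number from compound 1 to compound 3 (0.37 log units; beyond the scatter).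

Compound 4 `CCCCc1ccc(CN(CC)S(C)(=O)=O)c(=O)n1Cc1ccc(-c2ccccc2-c2nn[nH]n2)cc1` is not yet measured. Relative to compound 2 the change is methyl in place of phenyl on a saturated chain carbon bound to a sulfonamide nitrogen. Among the measured compounds shown here, no measured step swaps phenyl for methyl at this place. For the measured compounds named here, the steps that bear on it alter the whole group on the saturated chain carbon bound to an aromatic carbon: removing it entirely, a 3.5-fold higher number from compound 2 to compound 3 (0.54 log units; beyond the scatter), and exchanging acetamido for the sulfonamide-bearing group, a 1.5-fold lower number from compound 1 to compound 2 (0.18 log units; within the scatter). Since compound 4 retains the methylsulfonyl sulfonamide, a step within the scatter is expected in this assay, if anything toward a slightly higher number. For compound 4 the expected step is a 1.5-fold higher number from compound 2 to compound 4 (0.18 log units; within the scatter). The estimate for compound 4 in this assay is 3 nM, ranging from 1.5 nM to 6 nM.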

Compound 4, half-maximal inhibitory concentration: 2 nM
Compound 4: the middle estimate sits 1.5-fold (0.18 log units) above what was measured; the range from low to high includes it.
By their numbers in this assay, from the lowest: compounds 2, 4 and 1 (each within the scatter of the next); then compound 3.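

Putting methyl in place of phenyl on a saturated chain carbon bound to a sulfonamide nitrogen removes a six-membered aromatic ring of carbon only, yet this assay does not register the change (no change at the digits printed from compound 2 to compound 4 (within the scatter)), so the number of compound 2 does not depend on that ring. Ethyl(methylsulfonyl)amino also stays level with acetamido (a 1.5-fold lower number from compound 1 to compound 4 (0.18 log units; within the scatter)) and, like benzyl(methylsulfonyl)amino, holds a gain over hydrogen (a 3.5-fold lower number from compound 3 to compound 4 (0.54 log units; beyond the scatter)), so that gain is now seen with two sulfonamide groups rather than resting on the benzyl group alone. Nothing shown gives a reason why the phenyl can be lost without a change.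

Still open, going by these compounds, is how far this tolerance extends: a longer chain such as hexyl, a carboxylic acid or an amine in place of methyl on a saturated chain carbon bound to a sulfonamide nitrogen could behave differently. Also open, on these data alone, is whether the methylsulfonyl group itself contributes, which a plain ethylamino group on a saturated chain carbon bound to an aromatic carbon would address.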